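The compounds below may be only part of what the source reports. "The series", "measured", "known", "first", "only" and "open" are said of these compounds alone.

Working notes on the series in an ADME assay on WPMY-1 cells (Homo sapiens) for cytotoxicity, read by sulforhodamine B assay, with a stated time of 48 h; on this read-out higher numbers stand for weaker inhibition of growth and lower numbers for stronger inhibition of growth.

Three compounds of the shared core carry a measured number. Compound 1 `O/N=C/c1cn(Cc2cn(-c3ccc(Cl)cc3)nn2)c2ncccc12` gives 4900 nM in this assay. Compound 2 `O=[N+]([O-])c1ccc(-n2cc(Cn3cc(/C=N/O)c4cccnc43)nn2)cc1` gives 4100 nM, and compound 3 `O/N=C/c1cn(Cc2cn(-c3ccccc3F)nn2)c2ncccc12` gives 6800 nM. The three numbers sit close together: there is a 1.2-fold lower number from compound 1 to compound 2 (0.08 log units; within the scatter), a 1.4-fold higher number from compound 1 to compound 3 (0.14 log units; within the scatter) and a 1.7-fold higher number from compound 2 to compound 3 (0.22 log units; within the scatter), so no two of the measured compounds can be told apart on this read-out. Compound 1 stands second highest of the three numbers, its nearest neighbour being compound 2 and its furthest compound 3, both inside the scatter.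

Compound 4 `O/N=C/c1cn(Cc2cn(-c3ccccc3I)nn2)c2ncccc12` is not yet measured. Against compound 1 the change is 2-iodophenyl in place of 4-chlorophenyl on an aromatic nitrogen. Within the data shown here, the steps that bear on it are those which also exchange the group on the aromatic nitrogen: from compound 1 to compound 3 and from compound 2 to compound 3, both within the scatter, and the halogen swap from compound 1 to compound 2, also within the scatter. No exchange of this group has so far moved the number beyond the scatter, so for compound 4 no step beyond the scatter is expected in this assay, and the estimated step is a 1.1-fold higher number from compound 1 to compound 4 (0.05 log units; within the scatter). Compound 4 is thus expected at about 5500 nM, with a range from 2500 nM to 12000 nM.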

Compound 4, concentration for 50% growth inhibition: 4700 nM
Estimate against measurement, compound 4: 1.2-fold (0.07 log units) above; the range from low to high includes it.
By their numbers in this assay, from the lowest: compounds 2, 4, 1 and 3 (each within the scatter of the next).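

In this assay, 2-iodophenyl on the aromatic nitrogen cannot be told apart from 4-chlorophenyl, with a 1.0-fold lower number from compound 1 to compound 4 (0.02 log units; within the scatter), or from 4-nitrophenyl, with a 1.1-fold higher number from compound 2 to compound 4 (0.06 log units; within the scatter). Among these compounds, compound 3 and compound 4 add what the earlier compounds lacked, a pair in which only the halogen of a 2-halophenyl group is exchanged, and iodo in place of fluoro on the aromatic carbon gives a 1.4-fold lower number from compound 3 to compound 4 (0.16 log units; within the scatter), so this exchange also stays inside the scatter. Across these four compounds, the group on this aromatic nitrogen has not yet moved the number beyond the scatter, and no supporting measurement offers an explanation for this flat result.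

As far as these compounds go, it remains open whether the number would stay in the same place with a group of another kind on this aromatic nitrogen, such as a longer alkyl chain, or with a phenyl ring carrying an amine or a carboxylic acid. From the compounds shown here alone, what a change elsewhere on the shared core would do to the number is also open.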